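The compounds below may be only part of what the source reports. "The series", "measured", "known", "first", "only" and "open" are said of these compounds alone.

Three compounds have been measured in a functional assay on MCF7 cells (Homo sapiens) for antiproliferative activity, read by MTT assay, with a stated time of 24 h; on this read-out higher numbers stand for weaker inhibition and lower numbers for stronger inhibition:

Compound 1 `CCN(CC)CCNC(=O)C1CC(C(CC)(CC)c2ccc(C#CC(C)(C)O)c(C)c2)=CN1CC`: 3170 nM
Compound 2 `CCCC(O)(C#Cc1ccc(C(CC)(CC)C2=CCC(C(=O)NCCN(CC)CC)N2CC)cc1C)CCC`: 1360 nM
Compound 3 `CCN(CC)CCNC(=O)C1CC=C(C(CC)(CC)c2ccc(C#CC(O)C3CCCCC3)c(C)c2)N1CC`: 2790 nM

Compound 1, at 3170 nM, stands level with compound 3 within the scatter, and compound 2 shows a lower number than either. Compound 4 `CCN(CC)CCNC(=O)C1CC(C(CC)(CC)c2ccc(/C=C/C(O)(CC)CC)c(C)c2)=CN1CC` has not yet been measured. It departs from compound 1 at one place, on an aromatic carbon: a group of 8 heavy atoms (7 carbon, 1 oxygen; no ring) in place of a group of 6 heavy atoms (5 carbon, 1 oxygen; no ring), on an aromatic carbon. The group that leaves carries a triple bond outside aromatic rings, and the group that enters carries a double bond instead, still ortho to a methyl group.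

Among the measured compounds shown here, only one measured step touches this end of the molecule: a 2.1-fold higher number from compound 2 to compound 3 (0.31 log units; beyond the scatter). For the measured compounds named here, that step is modest, and it keeps the triple bond, so no measured pair tests its replacement. Compound 2, at 1360 nM, carries a larger open-chain group than compound 1, but the two also differ in the core. In this assay a small step is therefore expected, possibly within the scatter, leaning toward a lower number. The estimate is a 1.4-fold lower number from compound 1 to compound 4 (0.14 log units; within the scatter). Compound 4 is expected at 2300 nM, with an estimated range of 1000 nM to 5000 nM.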

Compound 4, half-maximal inhibitory concentration: 690 nM
Beside the measured number, compound 4's estimate is 3.3-fold (0.52 log units) above it; the measured number lies below the stated range.
By their numbers in this assay, from the lowest: compounds 4 and 2 (each within the scatter of the next); then compounds 3 and 1 (each within the scatter of the next).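

In this assay, the group on the aromatic carbon, ortho to a methyl group, moves the number beyond the scatter, with a 4.6-fold lower number from compound 1 to compound 4 (0.66 log units; beyond the scatter) as the result. Among the compounds shown here, this is the only measured step at this place in which the triple bond gives way to a double bond, whereas a 2.1-fold higher number from compound 2 to compound 3 (0.31 log units; beyond the scatter) kept the triple bond and exchanged one group of 8 heavy atoms for another. The double bond and the larger group arrive in the same step, so the share of each in the lower number cannot be separated, and no measurement at hand explains the change.

The compounds shown leave open what a triple-bonded chain carrying the same two ethyl groups on the hydroxyl-bearing carbon would give on the core of compound 4, and likewise what the double bond would give with the two methyl groups of compound 1 on that carbon. They also leave open whether an amine in place of the hydroxyl on this chain would keep the number of compound 4.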